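The source may report more compounds than this note shows. Statements on the series, on what has been measured and on what is new or still open speak of the compounds shown alone.

Working notes on the series, read in a functional assay on L1210 cells (Mus musculus) for antiproliferative activity, with a stated time of 48 h; on this read-out lower numbers stand for stronger inhibition and higher numbers for weaker inhibition. Compound 1 (`C=C(Br)C(=O)Nc1ccc(C(=O)/C=C/c2ccc(OC)cc2)cc1`) gives 900 nM and compound 2 (`C=C(Br)C(=O)Nc1ccc(C(=O)/C=C/c2ccccc2OC)cc1`) gives 1700 nM, so compound 2 stands within the scatter of compound 1. Compound 3 (`C=C(Br)C(=O)Nc1ccc(C(=O)/C=C/c2ccc(OC)cc2OC)cc1`) differs from compound 2 by one change: methoxy in place of hydrogen on an aromatic carbon. Within the data shown here, the only measured step that bears on it is a 1.9-fold higher number from compound 1 to compound 2 (0.28 log units; within the scatter), which relocates the methoxy group and stays within the scatter. No step beyond the scatter is therefore expected in this assay, in either direction. The estimated step is a 1.4-fold lower number from compound 2 to compound 3 (0.15 log units; within the scatter). Compound 3 is estimated at 1200 nM, with an expected range from 500 nM to 2800 nM.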

Compound 3, half-maximal inhibitory concentration: 520 nM
Compound 3: the middle estimate sits 2.3-fold (0.36 log units) above what was measured, and the stated range covers the measured number.
By their numbers in this assay, from the lowest: compounds 3, 1 and 2 (each within the scatter of the next, the first and the last beyond it).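

In this assay, among these compounds, methoxy in place of hydrogen on an aromatic carbon gives a 3.3-fold lower number from compound 2 to compound 3 (0.51 log units; beyond the scatter) and is the first step beyond the scatter, so this position, meta to a methoxy group and para to a large group, does register a change. Read from the other side, the same kind of change gives a 1.7-fold lower number from compound 1 to compound 3 (0.24 log units; within the scatter) and stays within the scatter, so the outcome depends on which methoxy is already present. Nothing at hand accounts for this step. Going by these compounds, whether a hydroxyl, a fluorine or an ethoxy group at this position would read the same remains open.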